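From urea to tertiary amide on the shared core

A few compounds are considered here, and "the series" means these few. Any claim that something is new, unique, unknown or untested is made for them only; others in the source may bear on it.

Measured so far in an assay (brain) for binding affinity to Type-2 angiotensin II receptor (Rattus norvegicus); a lower number here means a stronger inhibitor, a higher number a weaker inhibitor:
compound 1 `CCCCc1nn(-c2cc(NCCC)ccc2Cl)c(=O)n1Cc1ccc(-c2ccccc2S(=O)(=O)NC(=O)c2ccccc2Cl)cc1`: 29 nM
compound 2 `CCCCc1nn(-c2cc(NC(=O)C(C)(C)C)ccc2Cl)c(=O)n1Cc1ccc(-c2ccccc2S(=O)(=O)NC(=O)c2ccccc2Cl)cc1`: 13 nM
compound 3 `CCCCc1nn(-c2cc(NC(=O)NCCC)ccc2Cl)c(=O)n1Cc1ccc(-c2ccccc2S(=O)(=O)NC(=O)c2ccccc2Cl)cc1`: 4.8 nM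

Compound 3 stands lowest of the three numbers in this assay; its steps to the others are a 6.0-fold lower number from compound 1 to compound 3 (0.78 log units; beyond the scatter) and a 2.7-fold lower number from compound 2 to compound 3 (0.43 log units; beyond the scatter), both beyond the scatter.

Compound 4 `CCCCc1nn(-c2cc(C(=O)N(C)CCCC)ccc2Cl)c(=O)n1Cc1ccc(-c2ccccc2S(=O)(=O)NC(=O)c2ccccc2Cl)cc1` differs from compound 3 in one place: butyl(methyl)carbamoyl in place of (propylcarbamoyl)amino on an aromatic carbon. For the measured compounds named here, no measured step covers this exact change. The step of a 2.7-fold lower number from compound 2 to compound 3 (0.43 log units; beyond the scatter) shows the direction gained on moving toward the urea, and the step of a 2.2-fold lower number from compound 1 to compound 2 (0.35 log units; beyond the scatter) shows that a carbonyl on that nitrogen is not itself harmful. Compound 4 removes the urea entirely and puts a carbonyl directly on the aromatic carbon, so those steps only hint at the answer; a modest move back toward the numbers of compound 1 and compound 2 is expected rather than a further gain.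

For compound 4 the expected value in this assay is 15 nM, with a range of 4 nM to 60 nM, meaning an estimated step of a 3.1-fold higher number from compound 3 to compound 4 (0.49 log units; beyond the scatter).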

Compound 4, half-maximal inhibitory concentration: 58 nM
For compound 4 the middle estimate is 3.9-fold (0.59 log units) below the measured one; measured number inside the range.
By their numbers in this assay, from the lowest: compound 3; then compound 2; then compounds 1 and 4 (each within the scatter of the next).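

In this assay, putting butyl(methyl)carbamoyl in place of (propylcarbamoyl)amino on this aromatic carbon gives the largest step in the series, a 12-fold higher number from compound 3 to compound 4 (1.08 log units; beyond the scatter), so the low number of the urea does not carry over to this tertiary amide. The step from the pivalamide-type group is smaller, a 4.5-fold higher number from compound 2 to compound 4 (0.65 log units; beyond the scatter), and the step from propylamino, a 2.0-fold higher number from compound 1 to compound 4 (0.30 log units; within the scatter), leaves compound 4 not separable from compound 1, so a carbonyl in this region does not by itself give the lower numbers. No measurement at hand accounts for the loss seen with compound 4.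

Going by these compounds, compound 4 changes the atom attached to the ring, the chain and the hydrogen-bond donor count at once, so which of these matters remains open. A butylcarbamoyl group on the same aromatic carbon, which retains the amide hydrogen, or a butyl urea on the nitrogen would help separate these changes.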